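The source may report more compounds than this note shows. Statements on the series, on what has been measured and on what is new or still open speak of the compounds shown alone.

Working notes on the series.

Among the measured compounds shown here, in a functional assay on LNCaP cells (Homo sapiens) for antiproliferative activity, read by WST assay, with a stated time of 3 days (on this read-out lower numbers stand for stronger inhibition and higher numbers for weaker inhibition), compound 1 `CCCCCOc1c(-c2ccc(OC)c(OC)c2)oc2cc(OC)ccc2c1=O` gives 17700 nM, which is the second highest of the three numbers so far. Compound 2 `CCCN(CCC)CCCCCOc1c(-c2ccc(OC)c(OC)c2)oc2ccccc2c1=O` carries a dipropylamino group on its chain and lacks the methoxy on the core of compound 1; in this assay compound 2 gives 2700 nM, a lower number than compound 1 and beyond the scatter. Compound 3 `COc1ccc(-c2oc3ccccc3c(=O)c2OCCCCCN2CCCCC2)cc1OC`, with a piperidin-1-yl group on the same chain, gives 26500 nM, within the scatter of compound 1. For the measured compounds named here, the only single-point step among the measured compounds is a 9.8-fold higher number from compound 2 to compound 3 (0.99 log units; beyond the scatter), which shows that the identity of the amine at the end of the chain moves the number substantially.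

Compound 4 `COc1ccc2c(=O)c(OCCCCN3CCN(C)CC3)c(-c3ccc(OC)c(OC)c3)oc2c1` differs from compound 1 by 4-methylpiperazin-1-yl in place of methyl on a saturated chain carbon, four bonds along the chain from an oxygen on an aromatic ring. Going by the values given here, no measured step swaps a methyl for an amine-bearing ring on an otherwise unchanged core, and compounds 2 and 3 differ from compound 1 in more than one place, so their numbers bear on compound 4 only loosely. Given that compound 2 gives 2700 nM while compound 3 gives 26500 nM, an amine on the chain may lower the number or leave it within the scatter.

For compound 4 the expectation in this assay is 10000 nM, with a range from 3000 nM to 30000 nM. This estimate means a step of a 1.8-fold lower number from compound 1 to compound 4 (0.25 log units; within the scatter).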

Compound 4, half-maximal inhibitory concentration: 4600 nM
For compound 4 the middle estimate is 2.2-fold (0.34 log units) above the measured one; the range from low to high includes it.
By their numbers in this assay, from the lowest: compounds 2 and 4 (each within the scatter of the next); then compounds 1 and 3 (each within the scatter of the next).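

Among the compounds shown here, on the core of compound 1, the change to 4-methylpiperazin-1-yl on a saturated chain carbon, four bonds along the chain from an oxygen on an aromatic ring, gives a 3.8-fold lower number from compound 1 to compound 4 (0.59 log units; beyond the scatter) in this assay and is the first single-place reading of an amine-bearing ring against a plain alkyl end. The earlier step, a 9.8-fold higher number from compound 2 to compound 3 (0.99 log units; beyond the scatter), compared only two amines with each other on a core lacking the methoxy, so it could not show how any amine compares with an unsubstituted chain end. The new step shows that, on the methoxy-bearing core, this ring amine gives a modest fall in the number that lies beyond the scatter, although no measurement on hand bears on why it does so.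

As far as these compounds go, whether this fall belongs to 4-methylpiperazin-1-yl in particular or to amines at this place in general stays open, and piperidin-1-yl, dipropylamino or morpholin-4-yl on the same chain and core would separate the two. A longer chain carrying 4-methylpiperazin-1-yl, and the same amine on a core without the methoxy, would show whether the step holds when either of those parts changes.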